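Trifluoromethyl for methoxy in compound 2

A few compounds are considered here, and "the series" means these few. Any claim that something is new, unique, unknown or untested is made for them only; others in the source may bear on it.

Compound 1 `Cc1c(C(=O)Nc2c(F)cc(-c3cccc(F)c3)cc2F)nc2ccc(C(F)(F)F)cc2c1O` gives 29900 nM
Compound 2 `COc1ccc2nc(C(=O)Nc3c(F)cc(-c4cccc(F)c4)cc3F)c(C)c(C(=O)O)c2c1` gives 14300 nM

Both numbers come from a functional assay on Hep 3B2 cells (Homo sapiens) for antiproliferative activity, read by MTT assay, with a stated time of 24 h (a higher number here means a weaker inhibitor, a lower number a stronger inhibitor), and compound 2 holds the lower of the two, with compound 1 beyond the usual scatter above it. Compound 3 `Cc1c(C(=O)Nc2c(F)cc(-c3cccc(F)c3)cc2F)nc2ccc(C(F)(F)F)cc2c1C(=O)O` comes from compound 2 by one change, trifluoromethyl in place of methoxy on an aromatic carbon. Among the compounds with values here, no measured pair shows this change alone, so in this assay no shift beyond the scatter is expected, in either direction. The estimate gives a 1.1-fold higher number from compound 2 to compound 3 (0.05 log units; within the scatter) as the expected step. Compound 3 is expected at 16000 nM (estimated range 6500 nM to 38000 nM).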

Compound 3, half-maximal inhibitory concentration: 7570 nM
Beside the measured number, compound 3's estimate is 2.1-fold (0.33 log units) above it; the range from low to high includes it.
By their numbers in this assay, from the lowest: compounds 3 and 2 (each within the scatter of the next); then compound 1.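

In this assay, swapping methoxy for trifluoromethyl on this aromatic carbon gives a 1.9-fold lower number from compound 2 to compound 3 (0.28 log units; within the scatter), so the data separate neither group at this position. With trifluoromethyl held in place, the other aromatic carbon shows a clearer result, with carboxy in place of hydroxy giving a 3.9-fold lower number from compound 1 to compound 3 (0.60 log units; beyond the scatter). No measurement available here accounts for either step. From the compounds shown here alone, what an amine or a longer chain would give on the trifluoromethyl-bearing carbon remains open. So does whether the carboxy step would hold with methoxy in place of trifluoromethyl.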